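A few compounds are considered here, and "the series" means these few. Any claim that something is new, unique, unknown or untested is made for them only; others in the source may bear on it.

Compound 1 `CCC(C)C(NC(=O)c1ccc(C(CC)(CC)c2ccc(OCCC(O)(CC)CC)c(C)c2)n1CC)C(=O)OC` gives > 50000 nM in an ADME assay on L02 cells (Homo sapiens) for antiproliferative activity, read by MTT assay, with a stated time of 48 h (on this read-out lower numbers stand for stronger inhibition and higher numbers for weaker inhibition), as a limit and not a number. Among the compounds with values here, compound 2 `CCOC(=O)C(CC(=O)OC)NC(=O)c1ccc(C(CC)(CC)c2ccc(OCCC(O)(CC)CC)c(C)c2)n1CC` gives 4280 nM in this assay and so holds the only true number so far, with nothing yet measured on its stronger side. Compound 3 `CCn1c(C(=O)N(C)CCO)ccc1C(CC)(CC)c1ccc(OCCC(O)(CC)CC)c(C)c1` shares the core of compound 2 and differs by a group of 5 heavy atoms (3 carbon, 1 nitrogen, 1 oxygen; no ring) in place of a group of 12 heavy atoms (7 carbon, 1 nitrogen, 4 oxygen; no ring), on a carbonyl carbon; here (2-hydroxyethyl)(methyl)amino enters on a carbonyl carbon whose other neighbours are: aromatic carbon. Within the data shown here, one measured step bears on this change, namely an at least 11-fold lower number from compound 1 to compound 2 (1.06 log units; beyond the scatter) and it is large. It shows that this assay responds strongly to the group at this end of the molecule, though it rests on a single pair. The value 4280 nM of compound 2 came with the group that now leaves whole, so a step to a higher number, meaning weaker inhibition, is expected. The estimated change is a 3.5-fold higher number from compound 2 to compound 3 (0.54 log units; beyond the scatter) and its size remains uncertain. For compound 3 the expected value is 15000 nM with an estimated range from 3500 nM to 50000 nM in this assay and a real chance of a limit.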

Compound 3, half-maximal inhibitory concentration: 2050 nM
Estimate against measurement, compound 3: 7.3-fold (0.86 log units) above; the measured number lies below the stated range.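

Replacing the whole group of compound 2 on the carbonyl carbon with (2-hydroxyethyl)(methyl)amino does not cost inhibition in this assay: the outcome is a 2.1-fold lower number from compound 2 to compound 3 (0.32 log units; beyond the scatter), a modest step beyond the scatter, so the number of compound 2 does not depend on the larger group that leaves. The other comparison at this place reads an at least 24-fold lower number from compound 1 to compound 3 (1.38 log units; beyond the scatter), which gives the smallest group of the three the lowest number, though heavy-atom count alone does not order the series: compound 2 goes against such a trend, with a larger group than compound 1 and a lower number. Compound 1 remains a limit and not a number, so its steps give only a bound on their size: the limit of > 50000 nM in this assay, at which 1 of the 3 values shown sits.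

Still open, going by these compounds, is which part of (2-hydroxyethyl)(methyl)amino matters, a question that a plain dimethylamino group or a longer 3-hydroxypropyl chain on the same amide nitrogen would address. Also open, on these data alone, is how a carboxylic acid in place of the esters of compound 2 would read in this assay, given that all three comparisons rest on single pairs.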